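From nitro to chloro on an aromatic ring

A few compounds are considered here, and "the series" means these few. Any claim that something is new, unique, unknown or untested is made for them only; others in the source may bear on it.

In a functional assay on A-431 cells (Homo sapiens) for inhibition, read by MTT assay, with a stated time of 72 h (a lower number here means a stronger inhibitor, a higher number a weaker inhibitor), compound 1 (`Clc1ccc(-c2nnc(SCCCN3CCN(c4nc5ccccc5o4)CC3)o2)cc1`) gives 89600 nM and compound 2 (`O=[N+]([O-])c1ccc(-c2nnc(SCCCN3CCN(c4nc5ccccc5s4)CC3)o2)cc1`) gives 46500 nM as its measured value, so the two numbers lie within the scatter of each other and neither stands apart. Compound 3 (`Clc1ccc(-c2nnc(SCCCN3CCN(c4nc5ccccc5s4)CC3)o2)cc1`) has yet to be measured in this assay as well. Its change from compound 2 is chloro in place of nitro on an aromatic carbon with chloro in place of nitro on an aromatic carbon, para to a large group. For the measured compounds named here, no measured pair isolates this replacement, so the data give no direct size for it. The expectation starts from compound 2 at 46500 nM as the reference value, and no step beyond the scatter is expected in this assay in either direction. An expected 1.2-fold higher number from compound 2 to compound 3 (0.07 log units; within the scatter) would stay within the scatter. For compound 3 the estimate is 55000 nM with an expected range from 22000 nM to 120000 nM for the measurement.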

Compound 3, half-maximal inhibitory concentration: 69200 nM
Beside the measured number, compound 3's estimate is 1.3-fold (0.10 log units) below it; the range from low to high includes it.
By their numbers in this assay, from the lowest: compounds 2, 3 and 1 (each within the scatter of the next).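

For the compounds shown here, compound 3 provides the first pairs that differ in one place. In this assay, 4-nitrophenyl to 4-chlorophenyl gives a 1.5-fold higher number from compound 2 to compound 3 (0.17 log units; within the scatter) on an aromatic carbon para to a large group, so this assay does not separate chloro from nitro at this position. The second pair, with 1,3-benzothiazol-2-yl in place of 1,3-benzoxazol-2-yl on an amine nitrogen in a ring, gives a 1.3-fold lower number from compound 1 to compound 3 (0.11 log units; within the scatter) and likewise shows no separable effect, and no supporting evidence bears on either result.

The compounds shown leave open whether any other group at this position, such as an amine or a carboxylic acid, would move the number beyond the scatter. They also leave open whether a longer chain in the linker of the shared core would do so.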